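Moving Off the One Group That Gave a Number

The source may report more compounds than this note shows. Statements on the series, on what has been measured and on what is new or still open speak of the compounds shown alone.

In a functional assay on RT-112 cells (Homo sapiens) for antiproliferative activity, read by MTT assay, with a stated time of 72 h (on this read-out lower numbers stand for stronger inhibition of growth and higher numbers for weaker inhibition of growth), compound 1 (`COc1cc(Nc2ncnc3c(NC(=O)Nc4ccc([N+](=O)[O-])cc4)cccc23)cc(OC)c1`) gives > 20000 nM which is a limit of the assay and not a number. Among the compounds with values here, compound 2 (`COc1cc(Nc2ncnc3c(NC(=O)Nc4cccc(C(F)(F)F)c4F)cccc23)cc(OC)c1`) gives 471 nM and so holds the only true number so far. Within the data shown here, the one measured step (an at least 42-fold lower number from compound 1 to compound 2 (1.62 log units; beyond the scatter)) is large, though one end of it rests on a limit (the limit of > 20000 nM in this assay, at which 1 of the 2 values shown sits). It shows that exchanging a single group on the shared core can move the result strongly.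

Compound 3 (`COc1cc(Nc2ncnc3c(NC(=O)c4ccc(CN(C)C)cc4)cccc23)cc(OC)c1`) departs from compound 2 at that same end of the molecule (4-((dimethylamino)methyl)phenyl in place of (2-fluoro-3-(trifluoromethyl)phenyl)amino on a carbonyl carbon), with 4-((dimethylamino)methyl)phenyl in place of (2-fluoro-3-(trifluoromethyl)phenyl)amino on a carbonyl carbon. Among the measured compounds shown here, no measured step covers this exact exchange, so the forecast is uncertain. Still, the large step (an at least 42-fold lower number from compound 1 to compound 2 (1.62 log units; beyond the scatter)) suggests that the group in compound 2 matters, so losing it should more likely raise the number than lower it. The expected step (a 3.2-fold higher number from compound 2 to compound 3 (0.50 log units; beyond the scatter)) is an estimated moderate rise, toward weaker inhibition of growth. Compound 3 is expected near 1500 nM within an estimated range (250 nM to 10000 nM).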

Compound 3, concentration for 50% growth inhibition: 4370 nM
For compound 3 the middle estimate is 2.9-fold (0.46 log units) below the measured one, and the stated range covers the measured number.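

In this assay, the position on the carbonyl carbon still gives a measurable number when the (2-fluoro-3-(trifluoromethyl)phenyl)amino group leaves and 4-((dimethylamino)methyl)phenyl enters, but the exchange costs activity: a 9.3-fold higher number from compound 2 to compound 3 (0.97 log units; beyond the scatter). Measured against the 4-nitrophenyl compound, the same entering group gives an at least 4.5-fold lower number from compound 1 to compound 3 (0.66 log units; beyond the scatter), so a number in range does not depend on the fluorinated ring alone, although of these three the fluorinated group of compound 2 still gives the strongest inhibition of growth. Compound 1 remains at a limit and not a number, so this second step has only one firm end: the limit of > 20000 nM in this assay, at which 1 of the 3 values shown sits.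

The exchange from compound 2 to compound 3 alters two things at once, removing the amino nitrogen with its hydrogen-bond donor and replacing the ring with its substituents, and these compounds cannot show which of the two accounts for the rise. A compound keeping the amino nitrogen while carrying the 4-((dimethylamino)methyl)phenyl ring would separate these two changes, and a morpholine or a carboxylic acid in place of the dimethylamino group would test how much that end of the ring matters.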